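The source may hold more compounds than are shown below. What is called first, only, known or untested is meant among the compounds shown, and "the series" means these compounds.

Measured compounds:
compound 1 `Cc1ccc(S(=O)(=O)NC(=O)Nc2ccccc2C(=O)/C=C/c2ccccc2)cc1` — 25 ug/mL
compound 2 `COc1ccc(/C=C/C(=O)c2ccccc2NC(=O)NS(=O)(=O)c2ccc(C)cc2)cc1` — 28.1 ug/mL
compound 3 `CCc1cc(/C=C/C(=O)c2ccccc2NC(=O)NS(=O)(=O)c2ccc(C)cc2)cc(OC)c1OC` — 19.2 ug/mL

In an ADME assay on the whole organism for cytotoxicity, with Artemia salina as the target, with a stated time of 24 h (a lower number here means that less compound is needed, a higher number that more compound is needed for the effect), compound 3 holds the lowest of the three numbers, yet neither neighbour is separated from it beyond the scatter: a 1.3-fold lower number from compound 1 to compound 3 (0.11 log units; within the scatter) and a 1.5-fold lower number from compound 2 to compound 3 (0.17 log units; within the scatter). Compound 4 `Cc1ccc(S(=O)(=O)NC(=O)Nc2ccccc2C(=O)/C=C/c2ccccc2[N+](=O)[O-])cc1` differs from compound 3 in one place: 2-nitrophenyl in place of 3-ethyl-4,5-dimethoxyphenyl on a double-bonded chain carbon bound to a double-bonded chain carbon. Among the compounds with values here, the steps that bear on this position are the two just named, both within the scatter, and the further step a 1.1-fold higher number from compound 1 to compound 2 (0.05 log units; within the scatter) also stayed within it. Within the data shown here, no measured compound carries a nitro group, so nothing speaks directly to that part of the change. For compound 4 the estimated value in this assay is 22 ug/mL, with a range from 10 ug/mL to 48 ug/mL. This estimate means a step of a 1.1-fold higher number from compound 3 to compound 4 (0.06 log units; within the scatter), none beyond the scatter.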

Compound 4, concentration for half-maximal effect: 40.1 ug/mL
The estimate for compound 4 lay 1.8-fold (0.26 log units) below the measured number; the measured number falls inside the stated range.
By their numbers in this assay, from the lowest: compounds 3, 1, 2 and 4 (each within the scatter of the next, the first and the last beyond it).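

In this assay, a change of the aryl group on this double-bonded chain carbon now gives a step beyond the scatter, modest in size (a 2.1-fold higher number from compound 3 to compound 4 (0.32 log units; beyond the scatter)). Against phenyl and 4-methoxyphenyl, 2-nitrophenyl stays within the scatter (a 1.6-fold higher number from compound 1 to compound 4 (0.21 log units; within the scatter); a 1.4-fold higher number from compound 2 to compound 4 (0.15 log units; within the scatter)), so the separation holds only against 3-ethyl-4,5-dimethoxyphenyl. Nothing available accounts for this step.

Which part of the exchanged aryl group carries the step stays open, whether the nitro group or the loss of the ethyl and methoxy groups. Also open, from the compounds shown here alone, is how an amine or a carboxylic acid on this ring would read in this assay.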